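From cyclobutyl to cyclobutylmethyl on a sulfonamide nitrogen

The compounds below may be only part of what the source reports. "The series", "measured", "known", "first", "only" and "open" are said of these compounds alone.

Compound 1 `CCc1ccc(N(C2CCC2)S(=O)(=O)c2ccc3c(c2)C(O)CC(C2CCOCC2)O3)cc1` gives 3.69
Compound 2 `Cc1ccc(N(C2CCC2)S(=O)(=O)c2ccc3c(c2)C(O)CC(C2CCOCC2)O3)c(C)c1` gives 3.77
Compound 3 `Cc1cc(C(O)(C(F)(F)F)C(F)(F)F)ccc1N(CC(C)C)S(=O)(=O)c1ccc2c(c1)C(O)CC(C1CCOCC1)O2` gives 4.37

In a physicochemical assay for lipophilicity, at pH 7.4 (a higher number here means a more lipophilic compound, a lower number a more polar compound), compound 1 and compound 2 stand level within the scatter, while compound 3 lies higher, beyond it. Compound 4 `CCc1ccc(N(CC2CCC2)S(=O)(=O)c2ccc3c(c2)C(O)CC(C2CCOCC2)O3)cc1` differs from compound 1 by cyclobutylmethyl in place of cyclobutyl on a sulfonamide nitrogen with cyclobutylmethyl in place of cyclobutyl on a sulfonamide nitrogen. For the measured compounds named here, the only measured step is a number 0.08 log units higher from compound 1 to compound 2 (within the scatter) for 2,4-dimethylphenyl in place of 4-ethylphenyl on a sulfonamide nitrogen. It concerns a different group and gives no direct measure of this change. The entering group is the larger one, and a modest rise in this assay is expected, with the estimated step being a number 0.31 log units higher from compound 1 to compound 4 (beyond the scatter) in this reading. For compound 4 the estimated value is 4 with an expected range from 3.65 to 4.35 in this estimate.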

Compound 4, distribution coefficient: 4.01
The estimate for compound 4 lay 0.01 log units below the measured number; measured number inside the range.
By their numbers in this assay, from the lowest: compounds 1, 2 and 4 (each within the scatter of the next, the first and the last beyond it); then compound 3.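

In this assay, for the compounds shown here, cyclobutylmethyl in place of cyclobutyl on the sulfonamide nitrogen gives a number 0.32 log units higher from compound 1 to compound 4 (beyond the scatter), a direct measure of this change that the earlier compounds did not provide. The step lies beyond the scatter, whereas the aryl change at the same nitrogen gave a number 0.08 log units higher from compound 1 to compound 2 (within the scatter), which lies within it. Nothing available explains the size of the new step.

As far as these compounds go, it remains open whether a longer chain or an amine at this nitrogen would move the number further. Also open, from the compounds shown here alone, is whether the step would hold with 2,4-dimethylphenyl in place of 4-ethylphenyl.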